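Iodo in place of ethynyl: working notes

This account rests on a few compounds, and the source may have more. Where it says the series, first, only, none or still open, it means among the compounds named here.

- compound 1 `Cc1nc(N)c2c(-c3ccco3)cn([C@@H]3O[C@H](CO)[C@@H](O)[C@H]3O)c2n1`: > 20000 nM
- compound 2 `Cc1nc(N)c2c(-c3ccsc3)cn([C@@H]3O[C@H](CO)[C@@H](O)[C@H]3O)c2n1`: > 20000 nM
- compound 3 `C#Cc1cn([C@@H]2O[C@H](CO)[C@@H](O)[C@H]2O)c2nc(C)nc(N)c12`: 3290 nM

Among the compounds with values here, in a functional assay on K562 cells (Homo sapiens), read by MTT assay, with a stated time of 72 h (a higher number here means a weaker inhibitor, a lower number a stronger inhibitor), compound 3 gives 3290 nM, the only true number so far. Compound 1 gives > 20000 nM, which is a limit. Compound 2 gives > 20000 nM, also a limit. The rest of the series therefore sits at the limit of > 20000 nM in this assay, at which 2 of the 3 values shown sit.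

Compound 4 `Cc1nc(N)c2c(I)cn([C@@H]3O[C@H](CO)[C@@H](O)[C@H]3O)c2n1` is the next case, and the change is iodo in place of ethynyl on an aromatic carbon.

The measured steps all fall on this same aromatic carbon. They are an at least 6.0-fold lower number from compound 1 to compound 3 (0.78 log units; beyond the scatter) and an at least 6.0-fold lower number from compound 2 to compound 3 (0.78 log units; beyond the scatter), both one-sided, together with a step that the two limits leave unreadable from compound 1 to compound 2. They show that the group here can matter, but none of them involves iodo, so they give no direction for this swap. Both ring-bearing compounds reach the limit. Compound 3 with its small ethynyl gives 3290 nM. Iodo is also small and carries no ring, so no step beyond the scatter is expected. The expected step is a 1.1-fold lower number from compound 3 to compound 4 (0.04 log units; within the scatter).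

Compound 4 is estimated at 3000 nM, with an expected range of 600 nM to 15000 nM.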

Compound 4, half-maximal inhibitory concentration: 1110 nM
The estimate for compound 4 lay 2.7-fold (0.43 log units) above the measured number; the measured number falls inside the stated range.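

In this assay the two groups without a ring are now separated on this aromatic carbon, with a 3.0-fold lower number from compound 3 to compound 4 (0.47 log units; beyond the scatter). Swapping a ring-bearing group for iodo gives larger, one-sided steps, with an at least 18-fold lower number from compound 2 to compound 4 (1.25 log units; beyond the scatter) and with an at least 18-fold lower number from compound 1 to compound 4 (1.25 log units; beyond the scatter), so among these four compounds the two without a ring are the two that give a true number. Compound 1 and compound 2 remain limits of the assay, and the step between them cannot be read: the limit of > 20000 nM in this assay, at which 2 of the 4 values shown sit.

From the compounds shown here alone, whether the order seen with iodo and ethynyl extends to other small groups stays open, for example bromo, chloro, methyl or an amine on the same carbon. Going by these compounds, it is also open whether any ring at this carbon can give a true number, since a phenyl ring or a saturated ring such as cyclopropyl would test that beyond furan-2-yl and thiophen-3-yl.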